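The source may report more compounds than this note shows. Statements on the series, on what has been measured and on what is new or still open speak of the compounds shown alone.

Compound 2, `CCC1(Cc2ccccc2)OS(=O)(=O)C=C1OCc1ccc(OC)cc1`, is tested in an ADME assay on HEL cells (Homo sapiens) for cytotoxicity, with a stated time of 3 days (a higher number here means that more compound is tolerated, a lower number that less compound is tolerated), where compound 2 reaches > 200000 nM, a limit of the assay rather than a number. For the measured compounds named here, its one measured neighbour is compound 1, `CCC1(Cc2ccccc2)OS(=O)(=O)C=C1OCc1ccc([N+](=O)[O-])cc1`, which carries a nitro group where compound 2 carries a methoxy group. In this assay compound 1 gives < 200000 nM, again a limit and not a number. The step of a number no lower from compound 1 to compound 2 (the limit leaves the size open) cannot be sized because the limit of < 200000 nM in this assay, at which 1 of the 2 values shown sits, and the limit of > 200000 nM in this assay, at which 1 of the 2 values shown sits, leave only its direction open to reading. Compound 3, `CCC1(Cc2ccccc2)OS(=O)(=O)C=C1OCc1ccc(C)cc1`, differs from compound 2 as follows: methyl in place of methoxy on an aromatic carbon. Going by the values given here, the only measured step is the one from compound 1 to compound 2, which concerns a different change and has no readable size, so it offers no guide to the direction or size of the present change in this assay; no step beyond the scatter is expected. Compound 3 is therefore expected to give 200000 nM, within 100000 nM to 400000 nM. The step of a number no higher from compound 2 to compound 3 (the limit leaves the size open) is estimated to stay within the scatter, most likely as a limit once more.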

Compound 3, half-maximal cytotoxic concentration: 41500 nM
The estimate for compound 3 lay 4.8-fold (0.68 log units) above the measured number; measured number below the stated range.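

In this assay, swapping the 4-methoxyphenyl for the 4-methylphenyl gives an at least 4.8-fold lower number from compound 2 to compound 3 (0.68 log units; beyond the scatter), so this place on the aromatic ring, para to a large group, is not indifferent to what it carries, even when the change is as small as losing one oxygen atom. The earlier pair could show only a direction, whereas here compound 3 gives 41500 nM, the first true number among the compounds shown, and the cells tolerate less of it than of compound 2. The step from compound 1 to compound 3 cannot be read, because compound 1 stands at a limit and not at a number: the limit of < 200000 nM in this assay, at which 1 of the 3 values shown sits.

From the compounds shown here alone, with only nitro, methoxy and methyl at this place, it remains open whether the drop follows from the loss of the oxygen or from the methyl itself, and where compound 1 truly lies relative to compound 3. An amine, a carboxylic acid or a longer chain such as ethyl at the same carbon could show how far tolerance moves with the group held there.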